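Cyclohexyl for 3-fluorophenyl on the amine of compound 1

This account rests on a few compounds, and the source may have more. Where it says the series, first, only, none or still open, it means among the compounds named here.

Compound 1 `O=c1cc(NCc2cccc(F)c2)sc2c([N+](=O)[O-])cc(C(F)(F)F)cc12` carries a (3-fluorobenzyl)amino group on the shared core. In an ADME assay on Vero cells (Chlorocebus sabaeus) for cytotoxicity, read by MTT assay, with a stated time of 48 h (on this read-out lower numbers stand for stronger inhibition and higher numbers for weaker inhibition), compound 1 returns only a limit, > 64 ug/mL. Compound 2 `CN(Cc1ccccc1)c1nc(=O)c2cc(C(F)(F)F)cc([N+](=O)[O-])c2o1` gives a number in this assay, 3.84 ug/mL. Compound 3 `CC1CN(c2cc(=O)c3cc(C(F)(F)F)cc([N+](=O)[O-])c3s2)CCN1CC1CCCCC1`, which also carries a cyclohexylmethyl, again returns only a limit, > 64 ug/mL. Compound 1 thus stands at the limit of > 64 ug/mL in this assay, at which 2 of the 3 values shown sit.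

Compound 4 `O=c1cc(NCC2CCCCC2)sc2c([N+](=O)[O-])cc(C(F)(F)F)cc12` differs from compound 1 by cyclohexyl in place of 3-fluorophenyl on a saturated chain carbon bound to a nitrogen on an aromatic ring. Among the compounds with values here, no measured pair shows this change on its own in this assay. The step of a number no higher from compound 1 to compound 4 (the limit leaves the size open) is expected to be none beyond the scatter, with compound 4 likely remaining at the limit. The estimate for compound 4 in this assay is 64 ug/mL, within 32 ug/mL to 128 ug/mL.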

Compound 4, half-maximal inhibitory concentration: > 64 ug/mL
Compound 4: a limit, no number; the forecaster's own chance of this, stated with the estimate: 75%; the middle value lies on the limit itself.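

Within the data shown here, compound 1 and compound 4 both return only limits in this assay; no step between them can be read. The compounds shown leave open whether cyclohexyl in place of 3-fluorophenyl changes the value at all.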